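A Ring Swap on the Guanidine End of Compound 3

The source may hold more compounds than are shown below. What is called first, only, known or untested is meant among the compounds shown, and "the series" means these compounds.

Compound 1 `COc1ccc2c(c1)CCC(CNCCCNC1=NCCCN1)O2`: > 1000 nM
Compound 2 `c1ccc2c(c1)NCC(CNCCCNC1=NCCCN1)O2`: > 1000 nM
Compound 3 `c1ccc2c(c1)CCC(CNCCCNC1=NCCN1)O2`: 6.31 nM

Within the data shown here, in an assay on isolated protein (Bos taurus) with 5-hydroxytryptamine receptor 1D (Homo sapiens) as the target (on this read-out higher numbers stand for weaker inhibition and lower numbers for stronger inhibition), compound 3 gives 6.31 nM, the only number among the three. For compound 1 the value > 1000 nM is a limit of the assay, not a number. For compound 2 the value > 1000 nM is likewise a limit. Compound 3 therefore stands alone with a measured number, set against (the limit of > 1000 nM in this assay, at which 2 of the 3 values shown sit). Compound 4 `O=C1CCCN=C(NCCCNCC2CCc3ccccc3O2)N1` differs from compound 3 by a group of 8 heavy atoms (5 carbon, 2 nitrogen, 1 oxygen; one seven-membered non-aromatic ring with 2 hetero atoms) in place of a group of 5 heavy atoms (3 carbon, 2 nitrogen; one five-membered non-aromatic ring with 2 hetero atoms), on an amine nitrogen. Among the measured compounds shown here, no measured pair shows this change, so its size is open. Compounds 1 and 2, which carry a larger ring at this end than compound 3, both stop at the limit. The step of a 48-fold higher number from compound 3 to compound 4 (1.68 log units; beyond the scatter) is expected to point toward weaker binding. Compound 4 is expected near 300 nM, within 50 nM to 3000 nM.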

Compound 4, half-maximal inhibitory concentration: 158 nM
Estimate against measurement, compound 4: 1.9-fold (0.28 log units) above; measured number inside the range.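

Among these compounds, this pair is the first direct comparison at this position, and it shows that replacing the five-membered ring with the seven-membered ring weakens binding in this assay: a 25-fold higher number from compound 3 to compound 4 (1.40 log units; beyond the scatter). Even so, compound 4 gives a measured number and does not sit at the limit: the limit of > 1000 nM in this assay, at which 2 of the 4 values shown sit.

With only this one pair, the compounds shown cannot separate the effect of the larger ring from that of the added oxygen. As far as these compounds go, how a plain amine or a longer chain at this end would read also remains open.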